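Hydroxyphenyl position in a terphenyl-type series

The compounds below may be only part of what the source reports. "The series", "measured", "known", "first", "only" and "open" are said of these compounds alone.

Compound 1 `Oc1ccc(-c2cc(-c3cccs3)cc(-c3ccccc3O)n2)cc1` carries a 2-hydroxyphenyl group on the shared core. In a functional assay on DU-145 cells (Homo sapiens) for cytotoxicity, read by CCK-8 assay (on this read-out higher numbers stand for weaker inhibition and lower numbers for stronger inhibition), compound 1 gives only a limit, > 50000 nM, and no number. Compound 2 `Oc1ccc(-c2cc(-c3cccs3)cc(-c3cccc(O)c3)n2)cc1` differs by 3-hydroxyphenyl in place of 2-hydroxyphenyl on an aromatic carbon; in this assay compound 2 gives 1890 nM. The step is an at least 26-fold lower number from compound 1 to compound 2 (1.42 log units; beyond the scatter); it is read against (the limit of > 50000 nM in this assay, at which 2 of the 3 values shown sit), so only its lower bound is known.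

Compound 3 `Oc1ccccc1-c1cc(-c2cccnc2)cc(-c2ccccc2O)n1` shares with compound 1 the 2-hydroxyphenyl group but the difference between the two cores is not broken down here. In this assay compound 3 gives only a limit, > 50000 nM, and no number.

Compound 4 `Oc1cccc(-c2cc(-c3cccnc3)cc(-c3ccccc3O)n2)c1`, not yet measured in this assay, relates to compound 3 by 3-hydroxyphenyl in place of 2-hydroxyphenyl on an aromatic carbon. This is the same kind of change as in the measured pair, not the same one: in the measured pair the place is meta to a 4-hydroxyphenyl group and meta to a thiophen-2-yl group, whereas here it is meta to a 2-hydroxyphenyl group and meta to a pyridin-3-yl group.

Within the data shown here, the expectation for compound 4 rests on the single measured instance of this kind of change, which gave an at least 26-fold lower number from compound 1 to compound 2 (1.42 log units; beyond the scatter) starting from a limit, and on compound 3 sitting at > 50000 nM. The step from compound 3 is expected to be an at least 8.3-fold lower number from compound 3 to compound 4 (0.92 log units; beyond the scatter), smaller and less certain given the changed surroundings. For compound 4 the value is estimated at 6000 nM, expected between 1500 nM and 50000 nM, with a real chance that only a limit is again reported.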

Compound 4, half-maximal inhibitory concentration: 5580 nM
For compound 4 the middle estimate is 1.1-fold (0.03 log units) above the measured one; low and high end bracket the measured number.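

In this assay, 3-hydroxyphenyl in place of 2-hydroxyphenyl again gives a lower number on a second core, with an at least 8.9-fold lower number from compound 3 to compound 4 (0.95 log units; beyond the scatter), while the first core gave an at least 26-fold lower number from compound 1 to compound 2 (1.42 log units; beyond the scatter). The direction of the change therefore holds on both cores shown, which supports carrying it across these two, but two cores do not establish a rule for the wider series, and the steps can be set side by side only as lower bounds, not as sizes: the same change on two cores in this assay, an at least 26-fold lower number (1.42 log units; beyond the scatter) from compound 1 to compound 2 and an at least 8.9-fold lower number (0.95 log units; beyond the scatter) from compound 3 to compound 4; the limit leaves it open whether they differ. Neither step has a measured starting number, so neither shows how much the change is worth on its own core: the limit of > 50000 nM in this assay, at which 2 of the 4 values shown sit.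

The compounds shown leave open whether the thiophen-2-yl or pyridin-3-yl group, or the hydroxyphenyl group that stays in place on each core, alters the size of the step. They also leave open whether the hydroxyl of the 3-hydroxyphenyl group matters as such, or whether an amine, a methoxy group or a carboxylic acid at that point on the ring would give a similar number.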